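The source may hold more compounds than are shown below. What is called first, only, known or untested is meant among the compounds shown, and "the series" means these compounds.

Three compounds share one core and differ only in the group that hangs from a sulfur on the central ring. In a functional assay on MCF7 cells (Homo sapiens) for cytotoxicity, read by MTT assay, with a stated time of 72 h (on this read-out higher numbers stand for weaker inhibition and lower numbers for stronger inhibition), compound 1 `Cc1cc(S(=O)(=O)/N=C(\N)n2nccc2-c2ccccc2)c(SCc2ccc(Cl)cc2)cc1Cl` gives 75000 nM, compound 2 `Cc1cc(S(=O)(=O)/N=C(\N)n2nccc2-c2ccccc2)c(SCc2ccccc2Cl)cc1Cl` gives 24000 nM and compound 3 `Cc1cc(-c2ccccc2)n(/C(N)=N/S(=O)(=O)c2cc(C)c(Cl)cc2SCc2ccccc2C)n1` gives 80000 nM. Compound 3 carries the highest of the three numbers, yet its value and that of compound 1 sit within the scatter of each other, so the two cannot be told apart; only compound 2 stands clearly lower. For the measured compounds named here, the one step measured so far, a 3.1-fold lower number from compound 1 to compound 2 (0.49 log units; beyond the scatter), swapped 2-chlorophenyl for 4-chlorophenyl on a saturated chain carbon bound to a sulfur, a modest shift.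

Compound 4 `Cc1cc(-c2ccccc2)n(/C(N)=N/S(=O)(=O)c2cc(C)c(Cl)cc2SCc2ccccc2C(F)(F)F)n1` differs from compound 3 by trifluoromethyl in place of methyl on an aromatic carbon. Going by the values given here, no measured step exchanges methyl for trifluoromethyl anywhere in this set, so the step from compound 1 to compound 2 is the only guide, and it concerns a different change on the same ring. The shown data therefore give no reason to expect more than a small movement, in either direction, likely within the scatter. Compound 4 is expected to give about 60000 nM in this assay, between 20000 nM and 150000 nM. That estimate corresponds to an expected step of a 1.3-fold lower number from compound 3 to compound 4 (0.12 log units; within the scatter).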

Compound 4, half-maximal inhibitory concentration: 101000 nM
Compound 4: middle estimate off by 1.7-fold (0.23 log units), on the low side; the measured number falls inside the stated range.
By their numbers in this assay, from the lowest: compound 2; then compounds 1, 3 and 4 (each within the scatter of the next).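

In this assay, the exchange of methyl for trifluoromethyl gives a 1.3-fold higher number from compound 3 to compound 4 (0.10 log units; within the scatter), so a change from 1 heavy atom to 4 heavy atoms on this aromatic carbon leaves no readable difference between the two compounds. This result adds a second group to the comparison at this position: compound 2, with its 2-chlorophenyl group, gives 24000 nM, while compound 3 gives 80000 nM and compound 4 gives the value printed above, so neither the 2-methylbenzyl nor the 2-(trifluoromethyl)benzyl compound shares the number of compound 2. No measurement is available that could explain why these groups give the numbers they do.

As far as these compounds go, with a single chlorine compound on this side of the comparison, it remains open whether its number is particular to chlorine or would also appear with a bromine atom or a methoxy group in the same place. The compounds shown also leave open what the plain benzyl group, with only hydrogen at this position, would give, and whether a longer chain between the sulfur and the ring would change the picture.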